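Trifluoromethoxy for chloro on the cinnamamide ring

This account rests on a few compounds, and the source may have more. Where it says the series, first, only, none or still open, it means among the compounds named here.

The measured compounds in a functional assay on CHO-K1 cells for antagonist activity at melanin-concentrating hormone receptor 1 (Homo sapiens), read by inositol phosphate accumulation, with stated times of 10 min and 45 min; on this read-out lower numbers stand for stronger inhibition and higher numbers for weaker inhibition:
compound 1, `COCC(=O)NC1CCN(c2nc(C)c3cc(NC(=O)/C=C/c4ccc(OC(F)(F)F)cc4)ccc3n2)CC1`, gives 14 nM;
compound 2, `Cc1nc(NCCNS(C)(=O)=O)nc2ccc(NC(=O)/C=C/c3ccc(OC(F)(F)F)cc3)cc12`, gives 142 nM;
compound 3, `Cc1nc(N2CCC(N3CCCC3=O)CC2)nc2ccc(NC(=O)/C=C/c3ccc(Cl)cc3)cc12`, gives 20 nM.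

Among these three numbers compound 3 stands second highest. Its nearest neighbour is compound 1, whose number lies within the scatter of that of compound 3; its furthest is compound 2, which lies beyond the scatter on the weaker side. Within the data shown here, the one single-point step measured so far, a 10-fold higher number from compound 1 to compound 2 (1.01 log units; beyond the scatter), concerns the amine attached to the shared core, not the aryl ring of the cinnamamide, and so does not bear on the change examined here.

Compound 4, `Cc1nc(N2CCC(N3CCCC3=O)CC2)nc2ccc(NC(=O)/C=C/c3ccc(OC(F)(F)F)cc3)cc12`, differs from compound 3 by trifluoromethoxy in place of chloro on an aromatic carbon. Among the measured compounds shown here, no measured pair isolates this change. What the data do show is that compound 1 and compound 3, which carry the two different para groups but also different amines, sit within the scatter of each other in this assay. Compound 4 is therefore expected to show a step of a 1.3-fold lower number from compound 3 to compound 4 (0.12 log units; within the scatter) that stays within the scatter. On that basis compound 4 is estimated to give about 15 nM in this assay, with a likely range from 6 nM to 40 nM.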

Compound 4, half-maximal inhibitory concentration: 12 nM
Compound 4: middle estimate off by 1.3-fold (0.10 log units), on the high side, within the range that was stated.
By their numbers in this assay, from the lowest: compounds 4, 1 and 3 (each within the scatter of the next); then compound 2.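

Among these compounds, with the 4-(2-oxopyrrolidin-1-yl)piperidin-1-yl group held fixed, compound 3 and compound 4 isolate the change from 4-chlorophenyl to 4-(trifluoromethoxy)phenyl for the first time, and in this assay the result is a 1.7-fold lower number from compound 3 to compound 4 (0.22 log units; within the scatter). This place on the cinnamamide ring therefore holds chloro, with its single heavy atom, or trifluoromethoxy, with five heavy atoms, without a step beyond the scatter. With trifluoromethoxy kept, the group on the shared core gives the large step: 4-(2-oxopyrrolidin-1-yl)piperidin-1-yl in place of (2-(methanesulfonamido)ethyl)amino gives a 12-fold lower number from compound 2 to compound 4 (1.07 log units; beyond the scatter), whereas 2-oxopyrrolidin-1-yl in place of ((methoxymethyl)carbonyl)amino on the piperidine gives only a 1.2-fold lower number from compound 1 to compound 4 (0.07 log units; within the scatter), which stays within the scatter.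

The compounds shown leave open whether fluoro, methoxy or trifluoromethyl at the same aromatic carbon would also stay within the scatter, and whether the swap of chloro for trifluoromethoxy would read the same with (2-(methanesulfonamido)ethyl)amino on the core. Nothing given here accounts for any of these steps.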